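Arylpiperazine sulfonamides at the serotonin 7 receptor: methoxy position

The source may hold more compounds than are shown below. What is called first, only, known or untested is meant among the compounds shown, and "the series" means these compounds.

Measured compounds:
compound 1 `COc1ccc(N2CCN(CCCNS(=O)(=O)c3ccc(OC)cc3)CC2)cc1`: 9310 nM
compound 2 `COc1cccc(N2CCN(CCCNS(=O)(=O)c3ccc4ccccc4c3)CC2)c1`: 223 nM

In an assay on CHO cells for displacement of a labelled ligand from 5-hydroxytryptamine receptor 7 (Homo sapiens) (on this read-out higher numbers stand for weaker inhibition and lower numbers for stronger inhibition), compound 2 gives the lower of the two numbers recorded so far; compound 1 gives a markedly higher value, and the gap between the two is well beyond the scatter. Within the data shown here, compound 1 and compound 2 differ in two places at once, so no single-point step is available from the measured pair.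

Compound 3 `COc1ccc(N2CCN(CCCNS(=O)(=O)c3ccc4ccccc4c3)CC2)cc1` keeps the naphthyl sulfonamide of compound 2 and changes only the aryl on the piperazine: 4-methoxyphenyl in place of 3-methoxyphenyl on an amine nitrogen in a ring. The confounded comparison between compound 1 and compound 2 gives no clean reading of this change on its own. Some loss of potency relative to compound 2 is expected, of modest size, with the step from compound 2 to compound 3 estimated at a 2.7-fold higher number from compound 2 to compound 3 (0.43 log units; beyond the scatter). The expected value for compound 3 in this assay is 600 nM, with a range from 200 nM to 2500 nM.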

Compound 3, half-maximal inhibitory concentration: 3240 nM
Compound 3: the middle estimate sits 5.4-fold (0.73 log units) below what was measured; the whole stated range lies below it.
By their numbers in this assay, from the lowest: compound 2; then compound 3; then compound 1.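

In this assay the position of the methoxy on the aryl borne by the amine nitrogen in a ring matters on its own: 4-methoxyphenyl in place of 3-methoxyphenyl gives a 15-fold higher number from compound 2 to compound 3 (1.16 log units; beyond the scatter) with nothing else altered. With 4-methoxyphenyl held fixed, naphthalen-2-yl in place of 4-methoxyphenyl on a sulfonyl sulfur gives a 2.9-fold lower number from compound 1 to compound 3 (0.46 log units; beyond the scatter) and is the smaller of the two steps, so the gap between compound 1 and compound 2 does not rest on the sulfonyl aryl alone. No measurement at hand explains why the methoxy position carries this weight.

Open, from the compounds shown here alone, is whether the methoxy step keeps its size with a different sulfonyl aryl or a longer chain. Also open, going by these compounds, is how a 3-chlorophenyl or 3-hydroxyphenyl on the same nitrogen would compare with compound 2.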